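The source may hold more compounds than are shown below. What is called first, only, known or untested is meant among the compounds shown, and "the series" means these compounds.

Two compounds in this set have been followed in the same way. Compound 1 `C[C@@H]1CN(c2sc(C(F)(F)F)nc2-c2nc3cc(OCCO)ccc3[nH]2)CCN1C(=O)Cn1cnc2cccnc21` reaches 3000 nM in an ADME assay on the whole organism (Mus musculus, strain Balb/c) for pharmacokinetics, at a dose of 10 mg/kg by the oral route; on this read-out lower numbers stand for lower exposure and higher numbers for higher exposure at the dose given. Compound 2 `Cc1nc(C)n(CC(=O)N2CCN(c3sc(C(F)(F)F)nc3-c3nc4ccc(C5CCOCC5)cc4[nH]3)C[C@H]2C)n1` reaches 3360 nM in this assay, the higher of the two numbers, though the gap to compound 1 lies within the scatter, so the two cannot be told apart. Compound 3 `Cc1nc(C)n(CC(=O)N2CCN(c3sc(C(F)(F)F)nc3-c3nc4ccc(C5CCN(C)CC5)cc4[nH]3)C[C@H]2C)n1` has not yet been measured. It differs from compound 2 in one place: 1-methylpiperidin-4-yl in place of oxan-4-yl on an aromatic carbon. No measured pair in this set tells how such a swap acts on this read-out, so the direction of the step rests on nothing firmer than the two numbers shown. Compound 3 is expected to land at 1900 nM, within a range of 500 nM to 6000 nM. That estimate means a step of a 1.8-fold lower number from compound 2 to compound 3 (0.25 log units; within the scatter), which is expected to stay close to the scatter rather than stand clearly beyond it.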

Compound 3, maximal plasma concentration in the Mus musculus assay: 50.7 nM
The estimate for compound 3 lay 37-fold (1.57 log units) above the measured number, and the stated range ends above it.
By their numbers in the Mus musculus assay, from the lowest: compound 3; then compounds 1 and 2 (each within the scatter of the next).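

On an aromatic carbon of the six-membered carbon ring, 1-methylpiperidin-4-yl in place of oxan-4-yl gives, in the Mus musculus assay, a 66-fold lower number from compound 2 to compound 3 (1.82 log units; beyond the scatter), so a single ring swap at this position can change the read-out strongly, which compounds 1 and 2 could not show. In a physicochemical assay for lipophilicity, at pH 7.4 (on this read-out lower numbers stand for lower lipophilicity and higher numbers for higher lipophilicity), compound 2 gives 3.7 and compound 3 gives 3.4, two values within the scatter of each other, so this read-out does not separate the pair as the Mus musculus assay does. Nothing at hand gives a reason for the large step.

The compounds shown leave open which part of the new group goes with the step, the ring nitrogen or the methyl on it. An unsubstituted piperidin-4-yl group or a plain cyclohexyl ring at this place would speak to that.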